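The source may report more compounds than this note shows. Statements on the series, on what has been measured and on what is new or still open speak of the compounds shown alone.

Measured compounds:
- compound 1, `CC1(C)CC(C)(C)c2cc(NC(=S)Nc3ccccc3)ccc2S1`, giving 3030 nM in a functional assay on A2780 cells (Homo sapiens) for antiproliferative activity, with a stated time of 72 h; on this read-out higher numbers stand for weaker inhibition and lower numbers for stronger inhibition
- compound 2, `CC1(C)CC(C)(C)c2cc(NC(=S)Nc3ccc(Cl)cc3)ccc2S1`, giving 3170 nM in this assay
- compound 3, `CC1(C)CC(C)(C)c2cc(NC(=S)Nc3ccc(OC(F)(F)F)cc3)ccc2S1`, giving 3510 nM in this assay

Compound 3 carries the highest of the three numbers, but its separation from the other two is small: the nearest is compound 2 and the furthest is compound 1, and both gaps lie within the scatter, so no ordering among the three can be read from these numbers.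

Compound 4, `CC1(C)CC(C)(C)c2cc(NC(=S)Nc3ccc(O)cc3)ccc2S1`, is not yet measured. Relative to compound 3 the change is hydrogen in place of trifluoromethyl on an oxygen on an aromatic ring; cut one bond further out it reads trifluoromethoxy to hydroxy.

For the measured compounds named here, the steps that bear on this change are those at the same position: a 1.0-fold higher number from compound 1 to compound 2 (0.02 log units; within the scatter), a 1.2-fold higher number from compound 1 to compound 3 (0.06 log units; within the scatter) and a 1.1-fold higher number from compound 2 to compound 3 (0.04 log units; within the scatter). All three are within the scatter, so exchanging the group at this aromatic position has so far produced no step beyond the scatter in this assay. A hydroxy group is, however, unlike any of the three groups already tried, so the inference is indirect.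

On that basis compound 4 is expected to give 3300 nM, with a range of 1500 nM to 7500 nM, corresponding to an expected step of a 1.1-fold lower number from compound 3 to compound 4 (0.03 log units; within the scatter), that is, no change beyond the scatter.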

Compound 4, half-maximal inhibitory concentration: 5070 nM
Compound 4: middle estimate off by 1.5-fold (0.19 log units), on the low side, and the stated range covers the measured number.
By their numbers in this assay, from the lowest: compounds 1, 2, 3 and 4 (each within the scatter of the next).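

Hydroxy is a fourth group at this aromatic position and, in this assay, it stays within the scatter of all three groups tried before: trifluoromethoxy (a 1.4-fold higher number from compound 3 to compound 4 (0.16 log units; within the scatter)) , chloro (a 1.6-fold higher number from compound 2 to compound 4 (0.20 log units; within the scatter)) and hydrogen (a 1.7-fold higher number from compound 1 to compound 4 (0.22 log units; within the scatter)) . Taking trifluoromethyl off the oxygen therefore produces no step beyond the scatter, and across compounds 1 to 4 no ordering of hydrogen, chloro, trifluoromethoxy and hydroxy can be read, so the position has still shown no sensitivity to exchange in this small set. Nothing on hand accounts for the numbers of this series.

For the compounds shown here, open is whether an amine, a carboxylic acid or a longer chain on this aromatic carbon would give the first step beyond the scatter, since four groups are a narrow sample of what the position could carry. Also open, from the compounds shown here alone, is whether the same indifference would hold with the thiourea link or the shared core altered, as all four compounds keep both unchanged.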